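The source may hold more compounds than are shown below. What is called first, only, known or untested is meant among the compounds shown, and "the series" means these compounds.

Measured compounds:
- compound 1, `COc1cc(C)cc(-c2c(-c3ccnc(-c4ccc(C(C)=O)cc4)c3)cnn2CC#N)c1`, gives -4% in a functional assay on RPMI8266 cells (Homo sapiens) for cytotoxicity, read by sulforhodamine B assay, with a stated time of 48 h, tested at 1 uM; a higher number here means a weaker effect of the compound at the concentration tested, a lower number a stronger effect
- compound 2, `Cc1cc(O)cc(-c2nn(CC#N)cc2-c2ccnc(-c3ccc(Oc4ccccc4)cc3)c2)c1`, gives -20% in this assay

Compound 1 stands highest of the two numbers in this assay. Among the compounds with values here, its nearest neighbour is compound 2, whose value lies lower by an amount beyond the usual scatter of this kind of measurement; no step between the two has been worked out, so only the two values themselves can be compared, and they show compound 1 with the weaker effect of the pair.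

Compound 3, `COc1cc(C)cc(-c2c(-c3ccnc(-c4ccc(N(C)C)cc4)c3)cnn2CC#N)c1`, has not yet been measured in this assay. It differs from compound 1 in one place: dimethylamino in place of acetyl on an aromatic carbon. The group that leaves and the group that enters each count three heavy atoms and one hydrogen-bond acceptor, and neither carries a net charge.

Within the data shown here, with no comparable step among the measured compounds, the account rests on the value of compound 1 alone. The step from compound 1 to compound 3 is expected to be small, a number 1 percentage points lower from compound 1 to compound 3 (within the scatter), with no direction that can be told beyond the scatter. Compound 3 is therefore estimated at -5%, in a range from -20% to 10%.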

Compound 3, a percentage reported as activity, at one concentration (the size of the read-out at that concentration, not a potency): -31%
Beside the measured number, compound 3's estimate is 26 percentage points above it; the measured number lies below the stated range.
By their numbers in this assay, from the lowest: compound 3; then compound 2; then compound 1.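

The result shows that the position on the aromatic carbon, para to a large group, responds to what it carries: in this assay, dimethylamino in place of acetyl gives a number 27 percentage points lower from compound 1 to compound 3 (beyond the scatter), with the lower number marking the stronger effect. The earlier compounds shown here could not show this, as compound 1 and compound 2 differ in more than one place and offered no readable step. The leaving and entering groups match in their counts of heavy atoms and hydrogen-bond acceptors and neither carries a net charge, so these counts do not follow the step, and nothing measured here gives a reason for it.

A single pair leaves open whether the step comes from gaining dimethylamino or from losing acetyl, and how a primary amine, a morpholine ring or a carboxylic acid would read at the same position. It also leaves open whether the same exchange would give a step of similar size with other groups elsewhere on the shared core, such as the hydroxyl group carried by compound 2.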